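The source may report more compounds than this note shows. Statements on the series, on what has been measured and on what is new or still open speak of the compounds shown alone.

Measured compounds in a functional assay on HT-29 cells (Homo sapiens) for antiproliferative activity, read by MTT assay, with a stated time of 24 h, tested at 10 uM; on this read-out higher numbers stand for more inhibition at the one concentration tested (going by the name of the read-out) and lower numbers for less inhibition:
- compound 1, `O=C(NS(=O)(=O)c1ccc(Cl)cc1)n1ccc2cccnc21`: 54.4%
- compound 2, `Cc1ccc(S(=O)(=O)NC(=O)n2ccc3cccnc32)cc1`: 33.4%

Among the compounds with values here, compound 2 stands lowest of the two numbers so far; its nearest neighbour is compound 1, and the step of a number 21 percentage points lower from compound 1 to compound 2 (beyond the scatter) lies beyond the scatter, so the order between these two is real.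

Compound 3, `Cc1ccc(S(=O)(=O)NC(=O)n2ccc3cc(Br)cnc32)cc1`, is not yet measured. It differs from compound 2 by bromo in place of hydrogen on an aromatic carbon, the change sitting on the fused core of the shared scaffold rather than on the aryl ring that carries the sulfonyl group.

Within the data shown here, the one measured step, a number 21 percentage points lower from compound 1 to compound 2 (beyond the scatter), concerns a substituent exchange on the sulfonyl aryl ring and not the core, so it gives no direct reading on the present change. Among the measured compounds shown here, there is no step in which a substituent enters the core ring, and no pair of compounds that varies at that position. The step of a number 4.6 percentage points higher from compound 2 to compound 3 (within the scatter) is therefore expected to stay within the scatter, with the direction unknown.

Compound 3 is estimated at 38%, with a range of 15% to 62% in this assay.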

Compound 3, a percentage reported as inhibition, at one concentration (the size of the read-out at that concentration, not a potency): 82.4%
Estimate against measurement, compound 3: 44.4 percentage points below; the whole stated range lies below it.
By their numbers in this assay, from the lowest: compound 2; then compound 1; then compound 3.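

In this assay the aromatic carbon two atoms from the ring nitrogen proves to be a responsive position: bromo in place of hydrogen there gives a number 49 percentage points higher from compound 2 to compound 3 (beyond the scatter) and so shows that a single substitution on the shared core can move this read-out strongly. That step is large, while the earlier exchange on the aryl ring carrying the sulfonyl group, a number 21 percentage points lower from compound 1 to compound 2 (beyond the scatter), is modest, so the sulfonyl aryl ring is no longer the only place in the series where a change registers. No measurement at hand accounts for the rise that comes with the bromine atom.

Open, on these data alone, is whether an amine, a carboxylic acid or a longer chain on this same aromatic carbon would keep the inhibition seen with bromo, or whether the rise belongs to bromo alone. Also open, as far as these compounds go, is how the bromo on the core combines with the chloro on the sulfonyl aryl ring of compound 1, as each change is seen here only on its own and at a single concentration.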